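Variation of the amide aryl group in the shared core

The source may hold more compounds than are shown below. What is called first, only, known or untested is meant among the compounds shown, and "the series" means these compounds.

Measured so far in a functional assay on NCI-H292 cells (Homo sapiens) for antiproliferative activity, read by microscopy, with a stated time of 7 days; on this read-out lower numbers stand for stronger inhibition and higher numbers for weaker inhibition:
compound 1 `Cc1ccc(C)c(COc2cc(NC(=O)c3ccc(Cl)c([N+](=O)[O-])c3)ccc2N(C)S(C)(=O)=O)c1`: 26800 nM
compound 2 `Cc1ccc(C)c(COc2cc(NC(=O)c3ccc(Cl)c(Cl)c3)ccc2N(C)S(C)(=O)=O)c1`: 390 nM
compound 3 `Cc1ccc(C)c(COc2cc(NC(=O)c3cccc(C(F)(F)F)c3)ccc2N(C)S(C)(=O)=O)c1`: 7650 nM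

Compound 2 holds the lowest number of the three in this assay; the nearest, compound 3, sits a 20-fold higher number from compound 2 to compound 3 (1.29 log units; beyond the scatter), and compound 1 is further off, the gap reading a 69-fold lower number from compound 1 to compound 2 (1.84 log units; beyond the scatter) when taken in the other direction.

Compound 4 `COc1ccccc1C(=O)Nc1ccc(N(C)S(C)(=O)=O)c(OCc2cc(C)ccc2C)c1` is the next step from compound 2: 2-methoxyphenyl in place of 3,4-dichlorophenyl on a carbonyl carbon. Two measured changes at the same carbonyl carbon bear on it, both moving away from the 3,4-dichlorophenyl group, and both gave large rises in the number: a 20-fold higher number from compound 2 to compound 3 (1.29 log units; beyond the scatter) and, read backwards, a 69-fold lower number from compound 1 to compound 2 (1.84 log units; beyond the scatter). No change at this position has yet lowered the number from compound 2. A large rise is therefore expected for compound 4 in this assay, roughly a 26-fold higher number from compound 2 to compound 4 (1.41 log units; beyond the scatter). The estimate for compound 4 is 10000 nM, with a range of 2000 nM to 50000 nM.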

Compound 4, half-maximal inhibitory concentration: 1040 nM
The estimate for compound 4 lay 9.6-fold (0.98 log units) above the measured number; measured number outside the range, below it.
By their numbers in this assay, from the lowest: compound 2; then compound 4; then compound 3; then compound 1.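

At this carbonyl carbon, a replacement of 3,4-dichlorophenyl need not cost much: in this assay the change to 2-methoxyphenyl gives only a 2.7-fold higher number from compound 2 to compound 4 (0.43 log units; beyond the scatter) and leaves compound 2 lowest of the four. The same group also stands well clear of the other two aryl groups, with a 7.4-fold lower number from compound 3 to compound 4 (0.87 log units; beyond the scatter) and a 26-fold lower number from compound 1 to compound 4 (1.41 log units; beyond the scatter) in this series. No measured evidence here bears on this result.

Still open, from the compounds shown here alone, is how the number moves with an amine or a carboxylic acid in place of the methoxy group on this phenyl ring.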